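This account rests on a few compounds, and the source may have more. Where it says the series, first, only, none or still open, it means among the compounds named here.

Compound 1 `Cc1cc(NC(=O)Nc2ccc(C(C)(C)C)cc2)c2ccccc2n1`: > 25000 nM
Compound 2 `COc1ccc(NC(=O)Nc2cc(C)nc3ccccc23)cc1OC`: > 25000 nM
Compound 3 `Cc1cc(NC(=O)Nc2cc(Cl)cc(Cl)c2)c2ccccc2n1`: > 25000 nM

In an ADME assay on Raji cells (Homo sapiens) for cytotoxicity, with a stated time of 72 h (a higher number here means that more compound is needed for the effect, a lower number that less compound is needed), compound 1 reaches only a limit, > 25000 nM. Compound 2 likewise gives only a limit, > 25000 nM. Compound 3 too stops at a limit, > 25000 nM. Among the measured compounds shown here, because every value shown sits at the limit of > 25000 nM in this assay, at which 3 of the 3 values shown sit, compound 1 cannot be set above or below the other two; no compound gives a number. Compound 4 `Cc1cc(NC(=O)Nc2ccc(O)cc2)c2ccccc2n1` awaits measurement in this assay. It differs from compound 1 in one place, (hydroxy in place of tert-butyl on an aromatic carbon). For the measured compounds named here, no measured pair differing in one place exists here to show how such a change shifts this assay. The step from compound 1 to compound 4 is expected to be a step that the limit leaves unreadable from compound 1 to compound 4, essentially none beyond the scatter. Compound 4 is therefore estimated at 30000 nM, with a range from 10000 nM to 100000 nM.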

Compound 4, half-maximal effective concentration: > 25000 nM
Compound 4: no number, only a limit (the forecaster's own chance of this, stated with the estimate: 80%); the middle value is on the limit's open side.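

No step from compound 1 to compound 4 can be read in this assay, because both values are limits: the limit of > 25000 nM in this assay, at which 4 of the 4 values shown sit.

The compounds shown leave open how hydroxy in place of tert-butyl on an aromatic carbon shifts this assay, and whether any related compound gives a number there.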